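One Change Measured Twice in an Antiproliferative Series

A few compounds are considered here, and "the series" means these few. Any claim that something is new, unique, unknown or untested is made for them only; others in the source may bear on it.

Compound 1, `O=C(CCCCC[C@H](NC(=O)c1ccc(Br)cc1)C(=O)NCc1ccccc1)NO`, gives 1990 nM in a functional assay on MM96L cells (Homo sapiens) for antiproliferative activity; on this read-out lower numbers stand for stronger inhibition and higher numbers for weaker inhibition.
Compound 2, `O=C(CCCCC[C@H](NC(=O)OCc1ccccc1)C(=O)NCc1ccccc1)NO`, gives 1520 nM in this assay.
Compound 3, `O=C(CCCCC[C@H](NC(=O)c1ccc(Br)cc1)C(=O)NCc1ccncc1)NO`, gives 830 nM in this assay.

Compound 1 and compound 2 differ by one change, (benzyloxy in place of 4-bromophenyl on a carbonyl carbon), and this produced a 1.3-fold lower number from compound 1 to compound 2 (0.12 log units; within the scatter). Compound 3 and compound 4, `O=C(CCCCC[C@H](NC(=O)OCc1ccccc1)C(=O)NCc1ccncc1)NO`, differ by the same change, (benzyloxy in place of 4-bromophenyl on a carbonyl carbon), and the surroundings of the change are the same in both pairs. The two cores themselves differ by pyridin-4-yl in place of phenyl on a saturated chain carbon bound to an amide-type nitrogen, which gave a 2.4-fold lower number from compound 1 to compound 3 (0.38 log units; beyond the scatter).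

Among the compounds with values here, only one earlier example of the change exists, and it moved the number by little. Compound 4 is therefore expected to sit near compound 3, with a step of about a 1.3-fold lower number from compound 3 to compound 4 (0.11 log units; within the scatter) in this assay, resting on compound 3 giving 830 nM and on the earlier step being a 1.3-fold lower number from compound 1 to compound 2 (0.12 log units; within the scatter). Whether the second core reacts to this change as the first did cannot be checked from these three measurements, so the range is kept wide. For compound 4 the estimated value in this assay is 650 nM, between 300 nM and 1400 nM.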

Compound 4, half-maximal inhibitory concentration: 4320 nM
The estimate for compound 4 lay 6.6-fold (0.82 log units) below the measured number, and the stated range ends below it.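

The swap of 4-bromophenyl for benzyloxy did not carry over from the core of compound 1 to the core of compound 3 in this assay, where it gave a 5.2-fold higher number from compound 3 to compound 4 (0.72 log units; beyond the scatter), and the two steps disagree: the same change on two cores in this assay, a 1.3-fold lower number (0.12 log units; within the scatter) from compound 1 to compound 2 and a 5.2-fold higher number (0.72 log units; beyond the scatter) from compound 3 to compound 4, 6.8-fold (0.83 log units) apart, beyond the scatter of two such steps
Read the other way, putting pyridin-4-yl in place of phenyl gave a 2.8-fold higher number from compound 2 to compound 4 (0.45 log units; beyond the scatter), opposite in direction to its earlier step on the bromophenyl side: the same change on two cores in this assay, a 2.4-fold lower number (0.38 log units; beyond the scatter) from compound 1 to compound 3 and a 2.8-fold higher number (0.45 log units; beyond the scatter) from compound 2 to compound 4, 6.8-fold (0.83 log units) apart, beyond the scatter of two such steps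
So in these four compounds the two changes do not act independently, and the step from one core cannot simply be added to the other, but a single set of four compounds does not show why this happens or whether it holds for other groups.

Going by these compounds, it remains open whether a plain phenyl or a benzylamino group on the same carbonyl carbon would follow 4-bromophenyl or benzyloxy on the core of compound 3. A cyclohexyl in place of pyridin-4-yl could also show whether the reversal depends on that ring.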